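A few compounds are considered here, and "the series" means these few. Any claim that something is new, unique, unknown or untested is made for them only; others in the source may bear on it.

In a functional assay on the whole organism (strain ICR) with Mus musculus as the target, in the maximal electroshock model, with a stated time of 60 min (on this read-out lower numbers stand for an effect already at smaller amounts and higher numbers for an effect only at larger amounts of compound), compound 1 `CN(c1ccc(Br)cc1)c1nc(=O)c2cccnc2s1` gives 23.1 mg/kg, and compound 2 `CN(c1ccc(F)cc1)c1nc(=O)c2cccnc2s1` gives 15.3 mg/kg. Among the measured compounds shown here, these are the only two numbers available, and they lie within the scatter of each other, so compound 2 stands level with compound 1. Compound 3 `CN(c1ccc(OC(F)(F)F)cc1)c1nc(=O)c2cccnc2s1` differs from compound 2 by one exchange, trifluoromethoxy in place of fluoro on an aromatic carbon. For the measured compounds named here, the only measured step that bears on this exchange is a 1.5-fold lower number from compound 1 to compound 2 (0.18 log units; within the scatter), and it stayed within the scatter. Going by the values given here, no measured step involves trifluoromethoxy, so that evidence is thin and the range is kept wide. No shift beyond the scatter is therefore expected in this assay. The estimated 1.2-fold higher number from compound 2 to compound 3 (0.07 log units; within the scatter) reflects this. For compound 3 the expected value is 18 mg/kg, with an estimated range of 8 mg/kg to 40 mg/kg.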

Compound 3, dose for half-maximal effect: 25.2 mg/kg
For compound 3 the middle estimate is 1.4-fold (0.15 log units) below the measured one; measured number inside the range.
By their numbers in this assay, from the lowest: compounds 2, 1 and 3 (each within the scatter of the next).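

In this assay the exchange of fluoro for trifluoromethoxy gives a 1.6-fold higher number from compound 2 to compound 3 (0.22 log units; within the scatter) and stays level, and the exchange of bromo for trifluoromethoxy gives a 1.1-fold higher number from compound 1 to compound 3 (0.04 log units; within the scatter) and does the same. This position, on an aromatic carbon para to a large group, therefore accepts a group of five heavy atoms carrying a hydrogen-bond acceptor as well as the single fluorine, with all three compounds standing within the scatter of each other. Nothing available accounts for this flat result.

The compounds shown leave open whether an amine, a carboxylic acid or a longer chain on this carbon would stay level too. They also leave open whether a change elsewhere on the shared core would move the number beyond the scatter.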